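Hydroxy to nitro on the aromatic ring of compound 3

The source may hold more compounds than are shown below. What is called first, only, known or untested is meant among the compounds shown, and "the series" means these compounds.

Compounds measured in a functional assay on HT-1080 cells (Homo sapiens) for antiproliferative activity, read by MTT assay, with a stated time of 72 h (a higher number here means a weaker inhibitor, a lower number a stronger inhibitor), so far

compound 1 `COc1ccc(-c2c(-c3cc(OC)c(OC)c(OC)c3)ssc2=S)cc1N` gives 3000 nM
compound 2 `COc1ccc(-c2ssc(=O)c2-c2cc(OC)c(OC)c(OC)c2)cc1` gives 464 nM
compound 3 `COc1ccc(-c2ssc(=O)c2-c2cc(OC)c(OC)c(OC)c2)cc1O` gives 1910 nM

Compound 3 at 1910 nM lies in the upper part of this small set, within the usual scatter of compound 1 at 3000 nM and well apart from compound 2. Among the measured compounds shown here, the one measured step at the carbon in question is a 4.1-fold higher number from compound 2 to compound 3 (0.61 log units; beyond the scatter) for hydroxy in place of hydrogen on an aromatic carbon, a modest change beyond the scatter. For the measured compounds named here, compound 1 differs from the other two in more than one place and supplies no single step.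

Compound 4 `COc1ccc(-c2ssc(=O)c2-c2cc(OC)c(OC)c(OC)c2)cc1[N+](=O)[O-]` has not yet been measured. Going by the values given here, its change from compound 3 is nitro in place of hydroxy on an aromatic carbon, ortho to a methoxy group and meta to a large group nitro in place of hydroxy on an aromatic carbon and no measured step shows nitro there. Like compound 3 at 1910 nM it carries a group on that carbon, so the expectation stays close to that value, with no step beyond the scatter in this assay and only a slight lean to a lower number. The estimated step is a 1.5-fold lower number from compound 3 to compound 4 (0.17 log units; within the scatter) and it remains uncertain. For compound 4 the estimated value is 1300 nM with an expected range from 450 nM to 3800 nM as its limits.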

Compound 4, half-maximal inhibitory concentration: 4220 nM
Beside the measured number, compound 4's estimate is 3.2-fold (0.51 log units) below it; the measured number lies above the stated range.
By their numbers in this assay, from the lowest: compound 2; then compounds 3, 1 and 4 (each within the scatter of the next, the first and the last beyond it).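

Within this assay the exchange of hydroxy for nitro on this aromatic carbon gives a 2.2-fold higher number from compound 3 to compound 4 (0.34 log units; beyond the scatter) and shows that a second substituent can move the number further from that of the unsubstituted compound, so the earlier rise with hydroxy was not the limit at this position. Set against hydrogen, nitro gives a 9.1-fold higher number from compound 2 to compound 4 (0.96 log units; beyond the scatter) and this step is larger than a 4.1-fold higher number from compound 2 to compound 3 (0.61 log units; beyond the scatter) so among compounds 2, 3 and 4 hydrogen gives the lowest number and neither substituent goes against that order, while the loss of the hydrogen-bond donor of hydroxy does not bring the number back toward that of compound 2. No measurement shown here accounts for this order at the carbon ortho to the methoxy group.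

Three groups on one carbon cannot show whether the number follows the heavy-atom count of the group, the count of hydrogen-bond acceptors or something else, and a fluorine atom, a methyl group or a carboxylic acid on the same carbon would test that order. As far as these compounds go, compound 1 carries an amine there but differs from the others in more than one place, so the effect of that amine on the shared core remains open.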